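A few compounds are considered here, and "the series" means these few. Any claim that something is new, unique, unknown or untested is made for them only; others in the source may bear on it.

Compound 1 `Cc1cccc(/C=N/Nc2ncc3c(n2)n(C2CCCC2)c(=O)c(=O)n3C)c1` gives in a functional assay on HCT-116 cells (Homo sapiens) for antiproliferative activity, read by MTT assay (a higher number here means a weaker inhibitor, a lower number a stronger inhibitor), only a limit of the assay, > 100000 nM; it sits at the limit of > 100000 nM in this assay, at which 1 of the 2 values shown sits. Within the data shown here, compound 2 `Cn1c(=O)c(=O)n(C2CCCC2)c2nc(N/N=C/c3ccco3)ncc21` gives 78700 nM in this assay, and the measured step of an at least 1.2-fold lower number from compound 1 to compound 2 (0.10 log units; that floor lies within the scatter) is the only change recorded at this position. Compound 3 `Cn1c(=O)c(=O)n(C2CCCC2)c2nc(N/N=C/c3cc([N+](=O)[O-])ccc3Cl)ncc21` carries the change (2-chloro-5-nitrophenyl in place of 3-methylphenyl on a carbon with a double bond to nitrogen), so the step of an at least 1.2-fold lower number from compound 1 to compound 2 (0.10 log units; that floor lies within the scatter) is the one that bears on it; that step stays within the scatter. For compound 3 in this assay no step beyond the scatter is expected, and another limit is quite possible. Compound 3 is estimated at 100000 nM, in the range 40000 nM to 300000 nM, an expected step of a number no higher from compound 1 to compound 3 (the limit leaves the size open).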

Compound 3, half-maximal inhibitory concentration: 5610 nM
Compound 3: middle estimate off by 18-fold (1.25 log units), on the high side; measured number below the stated range.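

Among these compounds, on the carbon with a double bond to nitrogen, 2-chloro-5-nitrophenyl gives an at least 17-fold lower number from compound 1 to compound 3 (1.25 log units; beyond the scatter) and a 14-fold lower number from compound 2 to compound 3 (1.15 log units; beyond the scatter) in this assay as the first steps beyond the scatter at this position. The step between 3-methylphenyl and furan-2-yl had stayed within the scatter, so the position can respond strongly to the group it carries. For compound 1 the value is a limit of the assay, so the first step is a floor: the limit of > 100000 nM in this assay, at which 1 of the 3 values shown sits.

The compounds shown do not separate the contribution of the chlorine from that of the nitro group. On these data alone, how an amine or a carboxylic acid on the phenyl ring would compare also stays open.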